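Swapping an Imidazole for Dimethylamine on Two Cores

The source may hold more compounds than are shown below. What is called first, only, known or untested is meant among the compounds shown, and "the series" means these compounds.

Three compounds have been measured in a functional assay on the whole organism for agonist activity, with Mus musculus as the target; on this read-out higher numbers stand for an effect only at larger amounts of compound and lower numbers for an effect already at smaller amounts:

compound 1, `COC(=O)N(C)C(C)C#CCn1ccnc1`, gives 8 mg/kg
compound 2, `COC(=O)N(C)C(C)C#CCN(C)C`, gives 17.3 mg/kg
compound 3, `Cn1ccn(CC#CCn2ccnc2)c1=O`, gives 3.7 mg/kg

Compounds 1 and 2 share a core and differ in one place: dimethylamino in place of 1H-imidazol-1-yl on a saturated chain carbon bound to a triple-bonded carbon. This change gave a 2.2-fold higher number from compound 1 to compound 2 (0.33 log units; beyond the scatter), so compound 2 needs a larger dose than compound 1 for the same effect.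

Compound 3 carries a different core; the difference between the core of compound 3 and the core of compound 1 is not broken down here. Compound 3 has the lowest number of the three, and its step to each of the other two lies beyond the scatter.

Compound 4, `CN(C)CC#CCn1ccn(C)c1=O`, has not yet been measured in this assay. It is related to compound 3 by the same change that turns compound 1 into compound 2: dimethylamino in place of 1H-imidazol-1-yl on a saturated chain carbon bound to a triple-bonded carbon. The place of the change is described in identical words for both pairs, so the change is taken to be the same, occurring twice among the compounds shown.

Going by the values given here, with only one earlier example of this change, the expectation rests on compound 1 and compound 2, where the step was a 2.2-fold higher number from compound 1 to compound 2 (0.33 log units; beyond the scatter). A step of similar size is expected here, namely a 2.2-fold higher number from compound 3 to compound 4 (0.33 log units; beyond the scatter). On that basis compound 4 is estimated to give 8 mg/kg in this assay, expected to fall between 3.5 mg/kg and 18 mg/kg.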

Compound 4, dose for half-maximal effect: 8 mg/kg
Beside the measured number, compound 4's estimate shows no gap at the digits printed; the range from low to high includes it.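

In this assay, putting dimethylamino in place of 1H-imidazol-1-yl on a saturated chain carbon bound to a triple-bonded carbon gave a 2.2-fold higher number from compound 3 to compound 4 (0.33 log units; beyond the scatter), so the dimethylamino compound of this pair needs a larger dose for the same effect. Set beside the earlier example, the change gives a step of matching size on both cores: the same change on two cores in this assay, a 2.2-fold higher number (0.33 log units; beyond the scatter) from compound 1 to compound 2 and a 2.2-fold higher number (0.33 log units; beyond the scatter) from compound 3 to compound 4, 1.0-fold (0.00 log units) apart, within the scatter of two such steps This shows that, for these two pairs, the size of the step carried over from one core to the other, even though the two cores start from different numbers; it does not show that the same step would appear on a third core, and a dose read in the whole animal does not tell which difference between the two groups lies behind it.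

The compounds shown leave open how other groups in the same place would behave, for example diethylamino, a simple primary amine or a carboxylic acid, since dimethylamino is the only replacement for 1H-imidazol-1-yl seen here. They also leave open whether the step would keep its size if a longer chain carried the group.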